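This account rests on a few compounds, and the source may have more. Where it says the series, first, only, none or still open, it means among the compounds named here.

Compound 1 `Cc1ccsc1/C=C(/SCc1ccc(Cl)cc1)C(=O)c1ccc(Cl)cc1` belongs to a small set of open-chain enones that were tested in a functional assay on DU-145 cells (Homo sapiens) for inhibition, read by trypan blue exclusion, with a stated time of 96 h; on this read-out higher numbers stand for weaker inhibition of growth and lower numbers for stronger inhibition of growth. In this assay compound 1 gives 50000 nM, the highest of the two plain numbers in the set. Compound 2 `Cc1ccsc1/C=C(/SCc1ccc(Cl)cc1Cl)C(=O)c1ccc(Cl)cc1` gives 10000 nM, and the step of a 5.0-fold lower number from compound 1 to compound 2 (0.70 log units; beyond the scatter) comes from a chloro in place of hydrogen on an aromatic carbon. Compound 3 `Cc1ccsc1/C=C(/SCc1ccc(Cl)cc1)C(=O)c1ccc([N+](=O)[O-])cc1` carries a nitro in place of chloro on an aromatic carbon; its result is a limit of the assay, > 100000 nM, which records (the limit of > 100000 nM in this assay, at which 1 of the 3 values shown sits). The step of an at least 2.0-fold higher number from compound 1 to compound 3 (0.30 log units; that floor lies within the scatter) is therefore only a floor.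

Compound 4 `CSc1ccc(/C=C(/SCc2ccc(Cl)cc2)C(=O)c2ccc(Cl)cc2)cc1` is not yet measured. It differs from compound 1 at the far end of the chain: 4-(methylsulfanyl)phenyl in place of 3-methylthiophen-2-yl on a double-bonded chain carbon bound to a double-bonded chain carbon. Going by the values given here, neither measured step touches this part of the molecule, so no measured step bears directly on the change. The expectation is therefore a step of no more than the usual scatter, and compound 4 is estimated at 40000 nM, between 10000 nM and 150000 nM, which means an expected step of a 1.3-fold lower number from compound 1 to compound 4 (0.10 log units; within the scatter).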

Compound 4, concentration for 50% growth inhibition: 25000 nM
Beside the measured number, compound 4's estimate is 1.6-fold (0.20 log units) above it; the range from low to high includes it.
By their numbers in this assay, from the lowest: compound 2; then compounds 4 and 1 (each within the scatter of the next). At a limit, above all of these: compound 3.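

Going by these compounds alone, this is the first measured change at this end of the chain, and in this assay it gives a 2.0-fold lower number from compound 1 to compound 4 (0.30 log units; within the scatter). Replacing 3-methylthiophen-2-yl with 4-(methylsulfanyl)phenyl swaps a five-membered aromatic ring with 1 hetero atom for a six-membered ring of carbon only and raises the group from 6 to 8 heavy atoms, yet compounds 1 and 4 cannot be told apart on this read-out. So this place accepts a larger group without a change beyond the scatter, and no measurement shown gives a reason for this.

The compounds shown leave open whether a group of a different kind at this place, such as an amine or a carboxylic acid on the ring in place of methylsulfanyl, would move the number beyond the scatter. They also leave open whether adding a chloro in place of hydrogen on an aromatic carbon, the change that separates compound 2 from compound 1, would have a similar effect on compound 4.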